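A few compounds are considered here, and "the series" means these few. Any claim that something is new, unique, unknown or untested is made for them only; others in the source may bear on it.

Compound 2 `CC(=O)c1cc(/C=C/c2ccccc2)cc2cc(-c3ccccc3)[nH]c12` is the anchor for this step. In a functional assay on HeLa cells (Homo sapiens) for cytotoxicity, read by MTT assay, with a stated time of 2 days, tested at 100 uM (a lower number here means a stronger effect, a higher number a weaker effect of the compound at the concentration tested), compound 2 gives 21.3%. Within the data shown here, its only neighbour, compound 1 `CC(=O)c1cc(-c2ccc(F)cc2)cc2cc(-c3ccccc3)[nH]c12`, gives 24.8% in this assay, and the step of a number 3.5 percentage points lower from compound 1 to compound 2 (within the scatter) lies within the scatter, so the two numbers are to be read as the same effect.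

Compound 3 `CC(=O)c1cc(/C=C/c2ccc(F)cc2)cc2cc(-c3ccccc3)[nH]c12` is not yet measured. The change from compound 2 to compound 3 is fluoro in place of hydrogen on an aromatic carbon. Among the measured compounds shown here, no measured step carries fluorine onto an otherwise unchanged ring. For the measured compounds named here, the one step known, from compound 1 to compound 2, swaps a fluorine-bearing aryl for an ethenyl-linked aryl and stays within the scatter; compound 1 holds the fluorine at the same position of its ring and does not stand apart from compound 2. For compound 3 the expected step is therefore a number 0.7 percentage points higher from compound 2 to compound 3 (within the scatter), none beyond the scatter. Compound 3 is estimated at 22%, within 12% to 34%.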

Compound 3, a percentage reported as activity, at one concentration (the size of the read-out at that concentration, not a potency): 23.9%
Compound 3: middle estimate off by 1.9 percentage points, on the low side; the measured number falls inside the stated range.
By their numbers in this assay, from the lowest: compounds 2, 3 and 1 (each within the scatter of the next).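

Fluoro in place of hydrogen, para to a large group, can now be read directly with the 2-phenylethenyl unit otherwise unchanged: in this assay the result is a number 2.6 percentage points higher from compound 2 to compound 3 (within the scatter), so this change leaves the effect at the concentration tested unaltered. With the fluorine present in both compounds, 2-(4-fluorophenyl)ethenyl in place of 4-fluorophenyl gives a number 0.9 percentage points lower from compound 1 to compound 3 (within the scatter), so the earlier match between the two aryl arrangements also holds when only the ethenyl link differs. No supporting data bear on these results.

Going by these compounds, whether an amine or a carboxylic acid in place of fluoro would move the number beyond the scatter remains open. Among these compounds, also open is whether a longer chain in place of the 2-phenylethenyl unit would do so, and a single concentration gives no potency for any compound here.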